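Swapping the amine side group on a sulfamate scaffold

The source may hold more compounds than are shown below. What is called first, only, known or untested is meant among the compounds shown, and "the series" means these compounds.

The measured compounds so far, in an assay on HEK293 cells for inhibition of Steryl-sulfatase (Homo sapiens), tested at 0.1 uM; a lower number here means a weaker effect, a higher number a stronger effect of the compound at the concentration tested:
compound 1, `CCN(Cc1ccc(Br)cc1)c1ccc(C(=O)N2CCc3ccc(OS(N)(=O)=O)cc3C2)cc1`, gives 78.2%;
compound 2, `CCN(Cc1ccncc1)c1cccc(C(=O)N2CCc3ccc(OS(N)(=O)=O)cc3C2)c1`, gives 33.3%;
compound 3, `NS(=O)(=O)Oc1ccc2c(c1)CN(C(=O)c1cccc(N3CCN(Cc4ccccc4)CC3)c1)CC2`, gives 0%.

All three share the same core carrying the sulfamate group, and differ in the substituted aniline part attached through the amide. Compound 2 stands second highest of the three numbers. Its nearest neighbour is compound 3, whose number lies well below it, a gap beyond the usual scatter; its furthest neighbour is compound 1, whose number lies well above it, again beyond the scatter. No two of these compounds differ in only one place, so no single step between measured compounds can be read off.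

The compound still to be measured is compound 4, `CN(CCN1CCCCC1)c1cccc(C(=O)N2CCc3ccc(OS(N)(=O)=O)cc3C2)c1`. It differs from compound 2 in one place: methyl(2-(piperidin-1-yl)ethyl)amino in place of ethyl((pyridin-4-yl)methyl)amino on an aromatic carbon. The aromatic ring carrying one hetero atom is replaced by a saturated ring of the same size, with a two-carbon chain in between.

Within the data shown here, with no directly comparable step available, the size of the change in this assay is uncertain; a modest shift is expected, either within the scatter or somewhat downward, rather than a large jump. Compound 4 is expected to give about 28% in this assay, within a range of 5% to 55%, meaning an expected step of a number 5.3 percentage points lower from compound 2 to compound 4 (within the scatter).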

Compound 4, a percentage reported as inhibition, at one concentration (the size of the read-out at that concentration, not a potency): 24.5%
Compound 4: the middle estimate sits 3.5 percentage points above what was measured, and the stated range covers the measured number.
By their numbers in this assay, from the lowest: compound 3; then compounds 4 and 2 (each within the scatter of the next); then compound 1.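

In this assay, exchanging ethyl((pyridin-4-yl)methyl)amino for methyl(2-(piperidin-1-yl)ethyl)amino on an aromatic carbon, meta to a large group, gives a number 8.8 percentage points lower from compound 2 to compound 4 (within the scatter), so the two compounds cannot be told apart in this read-out. Among these compounds, this is the first single-place comparison, and it shows that, for this pair, a six-membered aromatic ring with one hetero atom can give way to a six-membered non-aromatic ring with one hetero atom, with the same count of heavy atoms, without a change beyond the scatter. No measurement shown here explains why the two groups read alike.

Compounds 1 and 3 each differ from compounds 2 and 4 in more than one place, so steps to them cannot be read, and the large spread in their values cannot be assigned to any single feature. Going by these compounds, it remains open whether a morpholine ring in place of the piperidine, a longer chain before the ring, or a simple dimethylamino group at the same place would keep this level of inhibition.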